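The compounds below may be only part of what the source reports. "The series", "measured", "known", "first", "only" and "open" are said of these compounds alone.

Compound 1 `CCCN(CCC(F)(F)F)Cc1c(C(F)(F)F)nc2n(-c3c(C)cc(C)cc3C)c(Cl)cn12` carries a propyl(3,3,3-trifluoropropyl)amino group on a saturated chain carbon bound to an aromatic carbon of the shared core. Going by the values given here, in an assay on cells for displacement of a labelled ligand from corticotropin-releasing factor receptor 1 (Homo sapiens), with a stated time of 100 min (on this read-out higher numbers stand for weaker inhibition and lower numbers for stronger inhibition), compound 1 gives 12 nM, the lowest of the two numbers known here. Among the compounds with values here, its nearest neighbour is compound 2 `Cc1cc(C)c(-n2c(Cl)cn3c(CN(CCC(F)(F)F)Cc4ccccc4)c(C(F)(F)F)nc23)c(C)c1`, which in this assay gives 43 nM; the one measured step, a 3.6-fold higher number from compound 1 to compound 2 (0.55 log units; beyond the scatter), comes from putting phenyl in place of ethyl on a saturated chain carbon bound to an amine nitrogen.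

Compound 3 `Cc1cc(C)c(-n2c(Cl)cn3c(CN4CCC(C)CC4)c(C(F)(F)F)nc23)c(C)c1` is not yet measured. It differs from compound 1 by 4-methylpiperidin-1-yl in place of propyl(3,3,3-trifluoropropyl)amino on a saturated chain carbon bound to an aromatic carbon. The step from compound 1 to compound 2 is the only one that bears on this, since it too alters what hangs on the amine nitrogen, and it was modest and towards a higher number. The change to compound 3 is larger, since the whole open-chain amine is exchanged for the 4-methylpiperidin-1-yl ring, so a step of similar or somewhat greater size towards a higher number is expected in this assay, that is a 5.0-fold higher number from compound 1 to compound 3 (0.70 log units; beyond the scatter). Compound 3 is therefore estimated at 60 nM in this assay, within a range of 15 nM to 250 nM.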

Compound 3, inhibition constant: 3200 nM
Beside the measured number, compound 3's estimate is 53-fold (1.73 log units) below it; the whole stated range lies below it.
By their numbers in this assay, from the lowest: compound 1; then compound 2; then compound 3.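

In this assay, the position on the saturated chain carbon bound to an aromatic carbon proves far less tolerant than the earlier pair suggested: exchanging propyl(3,3,3-trifluoropropyl)amino for 4-methylpiperidin-1-yl gives a 270-fold higher number from compound 1 to compound 3 (2.43 log units; beyond the scatter), whereas putting phenyl in place of ethyl on the open-chain amine gave only a 3.6-fold higher number from compound 1 to compound 2 (0.55 log units; beyond the scatter). Compound 1 and compound 2 both keep the 3,3,3-trifluoropropyl arm on an open-chain amine, while compound 3 has no such arm and ties its nitrogen into a ring, so this single change removes the three fluorine atoms and introduces the ring together, and the step cannot be divided between them. No measurement available here bears on why the step is so large.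

The compounds shown leave open whether the ring, the loss of the 3,3,3-trifluoropropyl arm or the methyl on the ring accounts for the step. A dipropylamino group would test the open-chain amine without fluorine, while an unsubstituted piperidin-1-yl ring or a morpholine ring would show how far the ring itself carries the step.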